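Sigma-1 binding notes: aryl swap on two thiophene cores

This account rests on a few compounds, and the source may have more. Where it says the series, first, only, none or still open, it means among the compounds named here.

Measured compounds, with their values in an assay on membranes from brain for displacement of a labelled ligand from Sigma non-opioid intracellular receptor 1 (Cavia porcellus), read by scintillation counting, with a stated time of 120 min; a higher number here means a weaker inhibitor, a lower number a stronger inhibitor:
- compound 1, `COC1Cc2c(csc2-c2cccc3ccccc23)C2(CCN(Cc3ccccc3)CC2)O1`: 5 nM
- compound 2, `COC1Cc2c(csc2-c2ccc(C#N)cc2)C2(CCN(Cc3ccccc3)CC2)O1`: 0.25 nM
- compound 3, `COC1Cc2cc(-c3ccc(C#N)cc3)sc2C2(CCN(Cc3ccccc3)CC2)O1`: 20 nM

Compound 2 and compound 3 share the same atoms joined differently; the difference between the two cores is not broken down here. Compound 3 stands highest of the three measured values, and its nearest neighbour is compound 1.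

On the core of compound 2, the change naphthalen-1-yl in place of 4-cyanophenyl on an aromatic carbon gives the step of a 20-fold higher number from compound 2 to compound 1 (1.30 log units; beyond the scatter). The unmeasured compound 4, `COC1Cc2cc(-c3cccc4ccccc34)sc2C2(CCN(Cc3ccccc3)CC2)O1`, carries the same change on the core of compound 3: naphthalen-1-yl in place of 4-cyanophenyl on an aromatic carbon. The surroundings of the place are not identical in the two pairs: in compound 2 the carbon is next to the ring atom that bears a fused ring and two ring bonds from the ring atom that bears a fused ring, whereas in compound 3 it is two ring bonds from two ring atoms that each bear a fused ring. Going by the values given here, it is therefore the same kind of change rather than the same change, and there is only one measured instance of it.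

The expectation for compound 4 rests on the step of a 20-fold higher number from compound 2 to compound 1 (1.30 log units; beyond the scatter) applied to compound 3 at 20 nM, so a step of about a 15-fold higher number from compound 3 to compound 4 (1.18 log units; beyond the scatter) is expected in this assay. Compound 4 is estimated at 300 nM in this assay, with a range from 60 nM to 1500 nM that allows for the differing surroundings of the place on the core of compound 3.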

Compound 4, inhibition constant: 12 nM
Beside the measured number, compound 4's estimate is 25-fold (1.40 log units) above it; the measured number lies below the stated range.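

In this assay, the new step, a 1.7-fold lower number from compound 3 to compound 4 (0.22 log units; within the scatter), lies within the scatter, so on this second core naphthalen-1-yl in place of 4-cyanophenyl leaves no measurable difference, and the large loss seen on the core of compound 2 does not carry over: the same change on two cores in this assay, a 20-fold higher number (1.30 log units; beyond the scatter) from compound 2 to compound 1 and a 1.7-fold lower number (0.22 log units; within the scatter) from compound 3 to compound 4, 33-fold (1.52 log units) apart, beyond the scatter of two such steps

For this series, the outcome of this change depends on the core, and a step read on one core cannot be transferred to the other as a fixed increment. The result does not show which feature of the two cores is responsible, as the cores differ in how their atoms are joined and the place of the change has different surroundings in each, and two pairs give no general rule for other aryl groups.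

The compounds shown leave open whether unsubstituted phenyl or 4-methoxyphenyl at this place would also give a large step on the core of compound 2 and none on the core of compound 3. They also leave open whether the same core dependence would hold with a phenethyl group in place of the benzyl group, or with a hydroxyl group in place of the methoxy group.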